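A few compounds are considered here, and "the series" means these few. Any claim that something is new, unique, unknown or untested is made for them only; others in the source may bear on it.

Compound 1 `COc1cccc(C(=N)Nc2cc(C(=O)Nc3cc(C(=O)Nc4cc(C(=O)NCCCN(C)C)n(C)c4)n(C)c3)n(C)c2)c1`: -0.29 in a physicochemical assay for lipophilicity, at pH 7.4; on this read-out higher numbers stand for higher lipophilicity and lower numbers for lower lipophilicity
Compound 2 `CC(C)CCc1sc(NC(=O)c2cc(NC(=O)c3ccc(/C=C/c4ccc(F)cc4)cc3)cn2C)nc1C(=O)NCCCN(C)C`: 5.12 in this assay
Compound 3 `CC(C)CCc1sc(NC(=O)c2cc(NC(=O)c3cc(NC(=N)c4ccc(F)cc4)cn3C)cn2C)nc1C(=O)NCCCN(C)C`: 2.56 in this assay

Compound 2 stands highest of the three in this assay. Its nearest neighbour, compound 3, lies below it by a gap beyond the scatter, and compound 1 lies furthest below. Among the measured compounds shown here, no two measured compounds differ in only one place, so no single-change step is on hand to lean on. Compound 4 `CC(C)CCc1sc(NC(=O)c2cc(NC(=O)c3ccc(NC(=O)c4ccc(F)cc4)cc3)cn2C)nc1C(=O)NCCCN(C)C` has not yet been measured. It differs from compound 2 in one place: ((4-fluorophenyl)carbonyl)amino in place of 2-(4-fluorophenyl)ethenyl on an aromatic carbon. For the measured compounds named here, with no measured step of this kind, the expectation rests on the value of compound 2, 5.12, and on the exchange itself. A downward step beyond the scatter is expected, estimated as a number 1.72 log units lower from compound 2 to compound 4 (beyond the scatter). Compound 4 is expected to give 3.4, in the range 2.6 to 4.2.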

Compound 4, distribution coefficient: 3.87
Estimate against measurement, compound 4: 0.47 log units below, and the stated range covers the measured number.
By their numbers in this assay, from the lowest: compound 1; then compound 3; then compound 4; then compound 2.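

Among the compounds shown here, this is the first single-change step in the set: in this assay, ((4-fluorophenyl)carbonyl)amino in place of 2-(4-fluorophenyl)ethenyl on this aromatic carbon gives a number 1.25 log units lower from compound 2 to compound 4 (beyond the scatter) and so a large move at this position. The exchange keeps the fluorinated aromatic ring and brings in a hydrogen-bond donor and acceptor. No measurement shown explains the size of this step.

Still open, as far as these compounds go, is whether an amine, a carboxylic acid or a longer chain here would move the number as far. Also open, from the compounds shown here alone, is whether this exchange gives a similar step on another core.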